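Swapping the Amide Substituent: From Compound 1 to Compound 4

The source may hold more compounds than are shown below. What is called first, only, known or untested is meant among the compounds shown, and "the series" means these compounds.

Measured so far:
compound 1, `CC(C)n1c(/C=C2\SC(=O)N(CC(=O)N3CCCC3)C2=O)nc2ccccc21`: > 50000 nM
compound 2, `Cn1c(/C=C2\SC(=O)N(CC(=O)N3CCOCC3)C2=O)nc2ccccc21`: 41100 nM
compound 3, `COc1cc2c(cc1OC)CN(C(=O)CN1C(=O)S/C(=C\c3nc4ccccc4n3C(C)C)C1=O)CC2`: 29700 nM

All three were tested in a functional assay on DU-145 cells (Homo sapiens) for inhibition, read by MTT assay, with a stated time of 48 h; a lower number here means a stronger inhibitor, a higher number a weaker inhibitor. Compound 1 gives > 50000 nM, which is a limit of the assay rather than a number, so its true potency is only known to sit at the limit of > 50000 nM in this assay, at which 1 of the 3 values shown sits. Within the data shown here, compound 2 gives 41100 nM and compound 3 gives 29700 nM; both are weak, and neither differs from compound 1 in only one place, so no single step in this assay has been measured yet.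

Compound 4, `CC(C)n1c(/C=C2\SC(=O)N(CC(=O)Nc3cc(C(C)(C)C)on3)C2=O)nc2ccccc21`, differs from compound 1 in one place: (5-(tert-butyl)-1,2-oxazol-3-yl)amino in place of pyrrolidin-1-yl on a carbonyl carbon. With every measured compound weak, the expectation for compound 4 is that it stays weak too; the step is estimated as an at least 1.6-fold lower number from compound 1 to compound 4 (0.22 log units; that floor lies within the scatter), a modest gain at most, hardly beyond the usual scatter. Compound 4 is expected to give about 30000 nM, most likely between 8000 nM and 100000 nM.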

Compound 4, half-maximal inhibitory concentration: > 50000 nM
Compound 4 gave a limit, no number; the forecaster's own chance of this, stated with the estimate: 40%; at least 1.6-fold (0.22 log units) between middle value and limit.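

Compound 1 and compound 4 both give a limit of the assay rather than a number, so no step between them can be read: the limit of > 50000 nM in this assay, at which 2 of the 4 values shown sit.

The compounds shown leave open whether (5-(tert-butyl)-1,2-oxazol-3-yl)amino in place of pyrrolidin-1-yl changes the strength of inhibition at all, and in which direction.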